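This account rests on a few compounds, and the source may have more. Where it says the series, first, only, none or still open, it means among the compounds named here.

Compound 1 `CCc1nc(-c2ccc(OC)c(OC)c2)c(C(=O)N2CCN(c3cccc(Cl)c3)CC2)o1` is tested in a functional assay on HL-60 cells (Homo sapiens) for inhibition, read by MTT assay, with a stated time of 72 h (on this read-out lower numbers stand for stronger inhibition and higher numbers for weaker inhibition), where compound 1 gives "not active" (no number reported), so no single number places it. Compound 2 `Cc1nc(-c2ccccc2F)c(C(=O)N2CCN(c3cc(Cl)ccc3C)CC2)o1` differs from compound 1 in several places; in this assay compound 2 gives 229 nM. Compound 3 `CCc1nc(-c2ccccc2Cl)c(C(=O)N2CCN(c3cccc(Cl)c3)CC2)o1` carries 2-chlorophenyl in place of 3,4-dimethoxyphenyl on an aromatic carbon. No measured pair isolates this change, so its size cannot be read from the data; on the numbers shown the step from compound 1 to compound 3 is expected to run toward stronger inhibition, beyond the scatter, with compound 2 the only guide. Compound 3 is therefore estimated at 1500 nM in this assay, expected within 250 nM to 10000 nM.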

Compound 3, half-maximal inhibitory concentration: 98.9 nM
Compound 3: the middle estimate sits 15-fold (1.18 log units) above what was measured; the measured number lies below the stated range.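

In this assay, among the compounds shown here, compound 1 has no number, so no step from it to compound 3 can be read. The compounds shown leave open how large this change of group alone is. No measurement at hand bears on this result.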